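A few compounds are considered here, and "the series" means these few. Any claim that something is new, unique, unknown or untested is made for them only; others in the source may bear on it.

Of the compounds shown here, three sharing one core have been tested in a functional assay on SW480 cells (Homo sapiens) for antiproliferative activity, read by MTT assay, with a stated time of 48 h; a higher number here means a weaker inhibitor, a lower number a stronger inhibitor. Compound 1 `CCCCCCCCC(CCO)n1cnc2c(Cl)ncnc21` gives 1370 nM. Compound 2 `OCCC(COCc1ccccc1)n1cnc2c(Cl)ncnc21` gives > 50000 nM, which is a limit of the assay and not a number. Compound 3 `CC(C)(C)[Si](C)(C)OCC(CCO)n1cnc2c(Cl)ncnc21` gives 31700 nM, the higher of the two actual numbers, and its gap to compound 1 lies well beyond the usual scatter.

The next compound, compound 4 `OCCC(CO)n1cnc2c(Cl)ncnc21`, is compound 3 without its large group: a hydrogen atom in place of a group of 7 heavy atoms (6 carbon, 1 silicon; no ring), on an oxygen on a saturated carbon. The group that leaves has no ring and no net charge, and only a hydrogen atom enters in its place.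

Going by the values given here, only one measured step touches that oxygen: an at least 1.5-fold lower number from compound 2 to compound 3 (0.19 log units; that floor lies within the scatter). It exchanges one large group for another, so it gives only a weak guide to removing the group altogether. Among the compounds with values here, still, compound 2 and compound 3, both with a large group on this oxygen, sit at the weak end of this assay, and nothing measured so far points to a gain once the group is gone. The expected step is small and towards a higher number: a 1.6-fold higher number from compound 3 to compound 4 (0.20 log units; within the scatter). The assay may well report only a limit here. For compound 4 the estimate is 50000 nM, with an expected range from 20000 nM to 120000 nM.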

Compound 4, half-maximal inhibitory concentration: > 50000 nM
Compound 4: no number, only a limit (the forecaster's own chance of this, stated with the estimate: 60%); the middle value sits exactly at the limit.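

In this assay, taking the large group off this oxygen brings no gain: the result is an at least 1.5-fold higher number from compound 3 to compound 4 (0.19 log units; that floor lies within the scatter), and since that floor lies within the scatter, it does not by itself prove a real loss. The clearer finding lies on the saturated chain carbon, where hydroxy in place of heptyl gives an at least 36-fold higher number from compound 1 to compound 4 (1.56 log units; beyond the scatter), the first step shown that links the one compound with a low number to another through a single change, and a large one. Compound 4 gives a limit and not a number, as does compound 2, so the step between these two cannot be read: the limit of > 50000 nM in this assay, at which 2 of the 4 values shown sit.

The compounds shown leave open whether heptyl itself is needed on that carbon or whether a shorter butyl chain or a longer decyl chain would serve as well. They also leave open how an amine or a carboxylic acid at the end of such a chain would fare in this assay, and how far past the limit compound 4 really lies.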